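The compounds below may be only part of what the source reports. "The series", "measured", "known", "first", "only" and "open" are said of these compounds alone.

Compound 1: `Cc1ccc2nc(-c3ccc(N)cc3Br)sc2c1` — in a functional assay on MDA-MB-468 cells (Homo sapiens) for inhibition (a lower number here means a stronger inhibitor, a higher number a weaker inhibitor), compound 1 gives < 0.1 nM, which is a limit of the assay and not a number.
Compound 2: `Nc1ccc(-c2nc3ccccc3s2)c(I)c1` — in this assay compound 2 gives < 0.1 nM, likewise a limit.
Compound 3: `Cc1ccc2nc(-c3ccc(N)cc3I)sc2c1` — in this assay compound 3 gives < 0.1 nM, again a limit.

All three values sit at the limit of < 0.1 nM in this assay, at which 3 of the 3 values shown sit. Compound 3 therefore stands at that limit, and no finer placing of it against the other two is possible. Two measured steps lead to compound 3, and neither can be sized: a step that the two limits leave unreadable from compound 1 to compound 3 and a step that the two limits leave unreadable from compound 2 to compound 3.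

The change from compound 3 to compound 4, `COc1ccc2nc(-c3ccc(N)cc3I)sc2c1`, is methoxy in place of methyl on an aromatic carbon. Within the data shown here, of the measured steps, the one from compound 2 to compound 3 also alters a small group on an aromatic carbon of the shared core, so it bears most directly on this change, but it is unreadable; the measured steps thus give neither a size nor a direction for the move in this assay. With compound 3 at the limit, compound 4 is expected to remain near it. The estimated step is a number no lower from compound 3 to compound 4 (the limit leaves the size open), not beyond the scatter. For compound 4 the estimate in this assay is 0.1 nM, ranging from 0.02 nM to 0.5 nM, with a fair chance that only a limit is reported again.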

Compound 4, half-maximal inhibitory concentration: < 0.1 nM
Compound 4 gave a limit, no number; the forecaster's own chance of this, stated with the estimate: 65%; the middle value lies on the limit itself.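

In this assay compound 4 gives < 0.1 nM, again a limit of the assay and not a number, so neither new step, from compound 3 or from compound 2 to compound 4, can be read: the limit of < 0.1 nM in this assay, at which 4 of the 4 values shown sit.

The compounds shown leave open whether exchanging methyl, methoxy, hydrogen, bromo or iodo changes inhibition at all.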